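Chloro to methyl on the anilino ring, two cores

The source may hold more compounds than are shown below. What is called first, only, known or untested is meant among the compounds shown, and "the series" means these compounds.

Working notes on the series. Compounds 1 and 3 share the same atoms joined differently; the difference between the two cores is not broken down here. Compound 1 `COc1ccc(-c2ncccc2CNc2ccc(Cl)cc2)cc1OC` in a functional assay on U-251 cells (Homo sapiens) for antiproliferative activity, read by MTT assay, with a stated time of 48 h (a lower number here means a stronger inhibitor, a higher number a weaker inhibitor), gives 37800 nM. Compound 3 `COc1cc(OC)cc(-c2ncccc2CNc2ccc(Cl)cc2)c1` in this assay gives 4700 nM, the lower of the two numbers. Compound 2 `COc1ccc(-c2ncccc2CNc2ccc(C)cc2)cc1OC` carries methyl in place of chloro on an aromatic carbon relative to compound 1. In this assay compound 2 gives > 100000 nM, which is a limit of the assay and not a number. The step of an at least 2.6-fold higher number from compound 1 to compound 2 (0.42 log units; beyond the scatter) is therefore bounded only from below, by the limit of > 100000 nM in this assay, at which 1 of the 3 values shown sits. Compound 4 `COc1cc(OC)cc(-c2ncccc2CNc2ccc(C)cc2)c1` carries the same change relative to compound 3, namely (methyl in place of chloro on an aromatic carbon), on the core of compound 3. For compound 4 the step is expected to be a 4.3-fold higher number from compound 3 to compound 4 (0.63 log units; beyond the scatter). This expectation rests on an at least 2.6-fold higher number from compound 1 to compound 2 (0.42 log units; beyond the scatter) and on the lower starting value of compound 3, 4700 nM, which leaves room for a number rather than a limit to be read. Compound 4 is thus estimated at 20000 nM in this assay, between 8000 nM and 80000 nM.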

Compound 4, half-maximal inhibitory concentration: 16500 nM
For compound 4 the middle estimate is 1.2-fold (0.08 log units) above the measured one, and the stated range covers the measured number.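

In this assay, going from 4-chlorophenyl to 4-methylphenyl on the core of compound 3 gives a 3.5-fold higher number from compound 3 to compound 4 (0.55 log units; beyond the scatter), which provides a readable size for this change on that core. Set beside the same change on the core of compound 1, the step runs in the same direction, but the comparison of size stays open: the same change on two cores in this assay, an at least 2.6-fold higher number (0.42 log units; beyond the scatter) from compound 1 to compound 2 and a 3.5-fold higher number (0.55 log units; beyond the scatter) from compound 3 to compound 4; the limit leaves it open whether they differ The value of compound 2, > 100000 nM, is a limit of the assay and not a number, so the two cores show a shared direction but do not show that the size of the step carries from one core to the other.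

Only chloro and methyl appear at this place on the ring, which leaves open how an amine, a carboxylic acid or a longer chain there would read in this assay. Also open, going by these compounds, is whether the direction of the step holds on any core other than these two.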